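A few compounds are considered here, and "the series" means these few. Any claim that something is new, unique, unknown or untested is made for them only; others in the source may bear on it.

In a functional assay on PBMC cells (Homo sapiens) for inhibition, with a stated time of 24 h (on this read-out higher numbers stand for weaker inhibition and lower numbers for stronger inhibition), compound 2 (`NCC1(c2cccc(-c3ccnc4[nH]ncc34)c2)CCOCC1`) gives 550 nM, within the scatter of compound 1 (`NCC1(c2cccc(-c3ccnc4[nH]ncc34)c2)CCCC1`), which gives 350 nM. Compound 3 (`Cc1cc(-c2ccnc3[nH]nc(C(F)(F)F)c23)cc(C2(CN)CCC2)c1`) gives 60 nM, a number lower than that of compound 2 by more than the scatter. Compound 4 (`NCC1(c2cccc(-c3ccnc4[nH]nc(C(F)(F)F)c34)c2)CCOCC1`) differs from compound 2 by one change, trifluoromethyl in place of hydrogen on an aromatic carbon. Within the data shown here, no measured pair isolates this change, but compound 3, at 60 nM, also carries trifluoromethyl on that carbon, alongside other differences. A step to a lower number in this assay, beyond the scatter, is therefore expected, estimated as a 5.0-fold lower number from compound 2 to compound 4 (0.70 log units; beyond the scatter). Compound 4 is expected at 110 nM, with an estimated range of 35 nM to 330 nM.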

Compound 4, half-maximal inhibitory concentration: 130 nM
Compound 4: middle estimate off by 1.2-fold (0.07 log units), on the low side, within the range that was stated.
By their numbers in this assay, from the lowest: compound 3; then compound 4; then compounds 1 and 2 (each within the scatter of the next).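

In this assay, trifluoromethyl in place of hydrogen on this aromatic carbon of the five-membered ring gives a 4.2-fold lower number from compound 2 to compound 4 (0.63 log units; beyond the scatter), a step beyond the scatter. Among these compounds, this is the first reading of the change on its own, since compound 3 carried trifluoromethyl only alongside other differences. Nothing measured here accounts for the step. The compounds shown leave open whether a methyl, a chlorine or a nitrile on this carbon would give a similar step. They also leave open whether trifluoromethyl would give the same step on compound 1.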